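The source may hold more compounds than are shown below. What is called first, only, known or untested is meant among the compounds shown, and "the series" means these compounds.

The shared core of these compounds is seen in compound 1, `COc1ccc(Nc2nc(Oc3cccc(NC(=O)C=C(C)C)c3)c3sccc3n2)cc1`, and in compound 3, `C=CC(=O)Nc1cccc(Oc2nc(Nc3cccc(OC)c3)nc3ccsc23)c1`; compound 2, `COc1ccc(Nc2nc(Oc3cccc(NC(=O)/C=C/C(C)C)c3)c3sccc3n2)cc1`, carries the same core with a different chain on the amide. In an ADME assay on L02 cells (Homo sapiens) for inhibition, read by MTT assay, with a stated time of 72 h (a lower number here means a stronger inhibitor, a higher number a weaker inhibitor), compound 1 gives 48900 nM. In this assay compound 3 gives 30300 nM, which is the lower of the two numbers reported, but its gap to compound 1 lies within the usual scatter of repeated measurements, so the two cannot be told apart on these figures. For compound 2 this assay records "not determined" (no result reported), so no number is available there.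

Compound 4, `C/C=C/C(=O)Nc1cccc(Oc2nc(Nc3cccc(OC)c3)nc3ccsc23)c1`, is the next member. Compared with compound 3 the change is prop-1-en-1-yl in place of vinyl on a carbonyl carbon, in words prop-1-en-1-yl in place of vinyl on a carbonyl carbon. Within the data shown here, no pair of measured compounds differing only in this way has been reported, so there is no measured step to lean on. With the two available numbers sitting so close together, the expectation is a step from compound 3 to compound 4 of a 1.1-fold higher number from compound 3 to compound 4 (0.02 log units; within the scatter), that is, none beyond the scatter in either direction. On that basis compound 4 is expected to give about 32000 nM in this assay, with a plausible range from 12000 nM to 80000 nM.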

Compound 4, half-maximal inhibitory concentration: 46000 nM
Compound 4: the middle estimate sits 1.4-fold (0.16 log units) below what was measured; low and high end bracket the measured number.
By their numbers in this assay, from the lowest: compounds 3, 4 and 1 (each within the scatter of the next).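

Among these compounds, this is the first measured step at this position, the carbonyl carbon of the amide: in this assay, putting prop-1-en-1-yl in place of vinyl gives a 1.5-fold higher number from compound 3 to compound 4 (0.18 log units; within the scatter) on the cell read-out. Because that step stays within the usual scatter, these two chains cannot be told apart on these figures, so a slightly larger group with its double bond kept at this carbonyl carbon shows no measurable change from the vinyl compound in this one pair. No measurement shown here offers an explanation for how these two numbers sit, so the pair records only the size of the step and gives no reason for it.

What the compounds shown leave open is whether any group at this carbonyl carbon can move the number beyond the scatter, for example a saturated ethyl chain, a longer chain, or a chain ending in a dimethylamino group. One pair within the scatter also cannot say whether the same swap would behave alike on a different core.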